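Thiophen-2-yl in place of acetoxymethyl: compound 4 expected

The compounds below may be only part of what the source reports. "The series", "measured", "known", "first", "only" and "open" are said of these compounds alone.

The three measured compounds and their values in a functional assay on A549 cells (Homo sapiens) for cytotoxicity, read by MTT assay, with a stated time of 72 h (a higher number here means that more compound is needed for the effect, a lower number that less compound is needed), are these.
Compound 1, `CCS[C@@H]1[C@H](SCC)[C@@H](Cn2cc(-c3ccc(F)cc3)nn2)O[C@H]1n1ccc(=O)[nH]c1=O`, gives 22900 nM.
Compound 2, `CCS[C@@H]1[C@H](SCC)[C@@H](Cn2cc(-c3cccc(C)c3)nn2)O[C@H]1n1ccc(=O)[nH]c1=O`, gives 12200 nM.
Compound 3, `CCS[C@@H]1[C@H](SCC)[C@@H](Cn2cc(COC(C)=O)nn2)O[C@H]1n1ccc(=O)[nH]c1=O`, gives only a limit, >= 100000 nM.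

Among the measured compounds shown here, compound 3 is thus the one compound of the three for which this assay returns no number: it sits at the limit of >= 100000 nM in this assay, at which 1 of the 3 values shown sits. The two compounds carrying an aromatic ring on that carbon do give numbers, and the step of a 1.9-fold lower number from compound 1 to compound 2 (0.27 log units; within the scatter) lies within the scatter. Against them compound 3 stands apart: an at least 4.3-fold higher number from compound 1 to compound 3 (0.64 log units; beyond the scatter) and an at least 8.1-fold higher number from compound 2 to compound 3 (0.91 log units; beyond the scatter).

Compound 4, `CCS[C@@H]1[C@H](SCC)[C@@H](Cn2cc(-c3cccs3)nn2)O[C@H]1n1ccc(=O)[nH]c1=O`, differs from compound 3 in one place: thiophen-2-yl in place of acetoxymethyl on an aromatic carbon. For the measured compounds named here, the steps that bear on this change are the two that run from an aromatic ring on that carbon to acetoxymethyl, both beyond the scatter and both toward a higher number. Compound 4 again carries an aromatic ring there, so it is expected to move back in the opposite direction, toward the numbers of compound 1 and compound 2, a step estimated as an at least 5.0-fold lower number from compound 3 to compound 4 (0.69 log units; beyond the scatter). In this assay compound 4 is therefore estimated at 20000 nM, with a range from 8000 nM to 60000 nM.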

Compound 4, half-maximal effective concentration: >= 100000 nM
Compound 4: no number, only a limit; the forecaster's own chance of this, stated with the estimate: 15%; middle value at least 5.0-fold (0.69 log units) away from the limit.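

Compound 4 shows that an aromatic ring on this carbon is not enough to bring a number back in this assay, as thiophen-2-yl leaves the compound at a limit, as acetoxymethyl did in compound 3: the limit of >= 100000 nM in this assay, at which 2 of the 4 values shown sit.

Among the compounds shown here, the change among aromatic groups now matters, with an at least 8.1-fold higher number from compound 2 to compound 4 (0.91 log units; beyond the scatter) and an at least 4.3-fold higher number from compound 1 to compound 4 (0.64 log units; beyond the scatter), whereas the only earlier step between two aromatic groups, a 1.9-fold lower number from compound 1 to compound 2 (0.27 log units; within the scatter), stayed small. Among the compounds shown, only the two with a substituted phenyl ring, compound 1 and compound 2, give numbers, while compound 3 and compound 4 do not, and the step between compound 3 and compound 4 cannot be read, so these two groups cannot be ranked against each other.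

The compounds shown do not tell whether a furan-2-yl or an unsubstituted phenyl on this carbon would give a number in this assay, and so they do not separate ring size from the sulfur of the thiophen-2-yl group. They also leave open how an aminomethyl group or a longer alkyl chain would read there.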